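Removing the Fluorine from the Anilino Group

The source may report more compounds than this note shows. Statements on the series, on what has been measured and on what is new or still open speak of the compounds shown alone.

Compound 1 `CCCCOc1ccc(-c2nc3ncccn3c2NCC2CCCCC2)cc1` gives 35000 nM in a toxicity assay on A549 cells (Homo sapiens) for cytotoxicity, read by luminescence and CellTiter-Glo, with a stated time of 48 h; a lower number here means that less compound is tolerated, a higher number that more compound is tolerated. Compound 2 `CCCCOc1ccc(-c2nc3ncccn3c2N)cc1` sits at a limit of this assay, > 100000 nM. Compound 3 `CCCCOc1ccc(-c2nc3ncccn3c2Nc2ccc(F)cc2)cc1` also sits at a limit of this assay, > 100000 nM.

Compound 3 therefore stands at the top of what this assay can report, and it shares that position with compound 2, since (the limit of > 100000 nM in this assay, at which 2 of the 3 values shown sit). Two of the steps among the measured compounds are readable: an at least 2.8-fold higher number from compound 1 to compound 2 (0.45 log units; beyond the scatter) and an at least 2.8-fold higher number from compound 1 to compound 3 (0.45 log units; beyond the scatter). The third, a step that the two limits leave unreadable from compound 2 to compound 3, cannot be sized because both ends are limits.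

Compound 4 `CCCCOc1ccc(-c2nc3ncccn3c2Nc2ccccc2)cc1` differs from compound 3 only in this way: hydrogen in place of fluoro on an aromatic carbon. Within the data shown here, no measured step changes this position on the ring, so nothing among the numbers speaks directly to it; the only nearby information is that compound 3 itself is tolerated up to the limit. Compound 4 is therefore expected to behave like compound 3, with a number no higher from compound 3 to compound 4 (the limit leaves the size open) falling within the scatter. The estimate for compound 4 in this assay is 100000 nM, in a range from 40000 nM to 250000 nM.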

Compound 4, half-maximal cytotoxic concentration: 100000 nM
Estimate against measurement, compound 4: no gap at the digits printed; the measured number falls inside the stated range.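

Without its fluoro group, compound 4 gives a plain number in this assay, 100000 nM. Compound 3 gives only a limit, > 100000 nM. The data give a number no higher from compound 3 to compound 4 (the limit leaves the size open) and a number no higher from compound 2 to compound 4 (the limit leaves the size open). With a bare phenyl group on the nitrogen, there is still a 2.9-fold higher number from compound 1 to compound 4 (0.46 log units; beyond the scatter), so the higher number seen against the cyclohexylmethyl group of compound 1 does not depend on the fluoro group being present. What the fluoro group itself contributes stays unknown, as these two steps that start from compound 2 and compound 3 cannot be read, because each starts from a limit: the limit of > 100000 nM in this assay, at which 2 of the 4 values shown sit.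

The compounds shown leave open what a larger group at this place on the ring, such as chloro or methoxy, would do. They also leave open whether an amine there would bring the number closer to that of compound 1, 35000 nM.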